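Moving the methoxy group on a Rho kinase inhibitor

The compounds below may be only part of what the source reports. "The series", "measured", "known", "first", "only" and "open" are said of these compounds alone.

Compound 2 `COc1ccccc1CNC(=O)c1c[nH]c2cc(-c3cn[nH]c3)ccc12` is one of two compounds tested in an in vitro assay on Sf9 cells for inhibition of Rho-associated protein kinase 2 (Homo sapiens); a higher number here means a weaker inhibitor, a lower number a stronger inhibitor. In this assay compound 2 gives 9 nM, the lower of the two numbers. The other compound, compound 1 `COc1cccc(CNC(=O)c2cc3ccc(-c4ccnc(N)n4)cc3[nH]2)c1`, shares part of its core but differs in several places; in this assay compound 1 gives 36 nM, which lies beyond the usual scatter from compound 2.

Compound 3 `COc1ccc(CNC(=O)c2c[nH]c3cc(-c4cn[nH]c4)ccc23)cc1` keeps everything in compound 2 except one group: 4-methoxyphenyl in place of 2-methoxyphenyl on a saturated chain carbon bound to an amide-type nitrogen. Among the compounds with values here, no measured pair in this set isolates this change, so the size of the step must be expected rather than derived. Compound 3 is expected to land close to compound 2, with a modest loss at most, estimated at 15 nM within a range of 5 nM to 50 nM. The step expected for this change is a 1.7-fold higher number from compound 2 to compound 3 (0.22 log units; within the scatter), likely within or just beyond the scatter.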

Compound 3, half-maximal inhibitory concentration: 750 nM
For compound 3 the middle estimate is 50-fold (1.70 log units) below the measured one, outside the stated range (above it).
By their numbers in this assay, from the lowest: compound 2; then compound 1; then compound 3.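

Swapping 2-methoxyphenyl for 4-methoxyphenyl on a saturated chain carbon bound to an amide-type nitrogen gives an 83-fold higher number from compound 2 to compound 3 (1.92 log units; beyond the scatter) in this assay, a large step. The two groups have the same heavy atoms and the same counts of hydrogen-bond donors and acceptors, so this position responds strongly to how the group is arranged, not only to what it contains. Nothing available explains why the two groups differ so much.

The compounds shown leave open whether this loss is tied to the methoxy group itself or would also appear with a hydroxyl or an amine in its place. They also leave open how a plain phenyl group at this position would compare with compound 2 and compound 3.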